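The compounds below may be only part of what the source reports. "The series", "measured", "known", "first", "only" and "open" are said of these compounds alone.

Two measured compounds share one core and differ only in the group on an aromatic carbon next to the ring nitrogen. Compound 1 `CC1CCCN1c1ccc2cc(NC(=O)CCc3ccc(C(F)(F)F)cc3)ccc2n1` gives 270 nM in a functional assay on HEK293 cells for activation of melanin-concentrating hormone receptor 1 (Rattus norvegicus), read by inositol phosphate accumulation; a lower number here means that less compound is needed, a higher number that more compound is needed for the effect. Compound 2 `O=C(CCc1ccc(C(F)(F)F)cc1)Nc1ccc2nc(N3CC4CC3CO4)ccc2c1` gives 70 nM in this assay, the lower of the two numbers; the step of a 3.9-fold lower number from compound 1 to compound 2 (0.59 log units; beyond the scatter) is modest yet beyond the scatter. Compound 3 `CNC(=O)NC1CCN(c2ccc3cc(NC(=O)CCc4ccc(C(F)(F)F)cc4)ccc3n2)C1` carries a group of 10 heavy atoms (6 carbon, 3 nitrogen, 1 oxygen; one five-membered non-aromatic ring with 1 hetero atom) in place of a group of 7 heavy atoms (5 carbon, 1 nitrogen, 1 oxygen; 2 five-membered non-aromatic rings with 1 hetero atom each), on an aromatic carbon. Among the compounds with values here, only the step from compound 1 to compound 2 bears on this position, and it shows that exchanging the group there shifts the number modestly rather than drastically. Nothing measured tells how a methylcarbamoylamino substituent on a pyrrolidine will fare, so the expectation is a step of a 2.1-fold higher number from compound 2 to compound 3 (0.33 log units; beyond the scatter), leaving compound 3 near compound 2 or somewhat higher, with wide uncertainty. Compound 3 is thus estimated at 150 nM in this assay, with a range from 45 nM to 500 nM.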

Compound 3, half-maximal effective concentration: 30 nM
Compound 3: middle estimate off by 5.0-fold (0.70 log units), on the high side, outside the stated range (below it).
By their numbers in this assay, from the lowest: compound 3; then compound 2; then compound 1.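

In this assay, the position on the aromatic carbon next to the ring nitrogen accepts a larger substituent with no loss: the 3-((methylcarbamoyl)amino)pyrrolidin-1-yl group gives a 2.3-fold lower number from compound 2 to compound 3 (0.37 log units; beyond the scatter), and a 9.0-fold lower number from compound 1 to compound 3 (0.95 log units; beyond the scatter). The earlier compounds shown here held only groups without hydrogen-bond donors, whereas this result shows that a group carrying such donors can give the lowest number of the three. No evidence available here accounts for the shift.

The compounds shown do not separate the contribution of the (methylcarbamoyl)amino part from that of the pyrrolidine bearing it. They also leave open how a plain amine, a carboxylic acid or a longer chain in place of the methyl on that part would fare.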